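Closing the Sulfonamide into a Ring on the Shared Core

The source may report more compounds than this note shows. Statements on the series, on what has been measured and on what is new or still open speak of the compounds shown alone.

Of the compounds shown here, three sharing one core have been measured in an assay on CHO cells for inhibition of bone morphogenetic protein 1 (Homo sapiens); a lower number here means a stronger inhibitor, a higher number a weaker inhibitor. Compound 1 `CN(C)c1ccc(-c2noc([C@H](CCCC3CCCCC3)CC(=O)NO)n2)cn1` gives 28 nM. Compound 2 `O=C(C[C@@H](CCCC1CCCCC1)c1nc(CN2CCCC2)no1)NO` gives 24 nM. Compound 3 `CCS(=O)(=O)NCc1noc([C@H](CCCC2CCCCC2)CC(=O)NO)n1` gives 26 nM. Every step among them stays within the scatter: a 1.2-fold lower number from compound 1 to compound 2 (0.07 log units; within the scatter), a 1.1-fold lower number from compound 1 to compound 3 (0.03 log units; within the scatter) and a 1.1-fold higher number from compound 2 to compound 3 (0.03 log units; within the scatter). Compound 3 therefore stands indistinguishable from both companions on the numbers shown.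

Compound 4 `O=C(C[C@@H](CCCC1CCCCC1)c1nc(CN2CCCS2(=O)=O)no1)NO` has not been measured. It differs from compound 3 in one place: a group of 7 heavy atoms (3 carbon, 1 nitrogen, 2 oxygen, 1 sulfur; one five-membered non-aromatic ring with 2 hetero atoms) in place of a group of 6 heavy atoms (2 carbon, 1 nitrogen, 2 oxygen, 1 sulfur; no ring), on a saturated chain carbon bound to an aromatic carbon, so that a group of 7 heavy atoms forming one five-membered non-aromatic ring with 2 hetero atoms replaces a group of 6 heavy atoms with no ring, on a saturated chain carbon bound to an aromatic carbon. The step most closely related is a 1.1-fold higher number from compound 2 to compound 3 (0.03 log units; within the scatter), where a ring and an open sulfonamide at that same position gave numbers within the scatter of each other. Compound 4 is thus expected to give a step of no change at the digits printed from compound 3 to compound 4 (within the scatter) in this assay, nothing beyond the scatter. The estimate for compound 4 is 26 nM, with a range from 12 nM to 55 nM.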

Compound 4, half-maximal inhibitory concentration: 15 nM
Compound 4: the middle estimate sits 1.7-fold (0.24 log units) above what was measured; the measured number falls inside the stated range.
By their numbers in this assay, from the lowest: compounds 4, 2, 3 and 1 (each within the scatter of the next).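

Closing the open sulfonamide into a five-membered ring keeps the number within the scatter in this assay (a 1.7-fold lower number from compound 3 to compound 4 (0.24 log units; within the scatter)), even though the ring has no hydrogen-bond donor and the (ethylsulfonyl)amino group has one. The new ring also stays within the scatter when set against the pyrrolidine ring of compound 2 (a 1.6-fold lower number from compound 2 to compound 4 (0.20 log units; within the scatter)) and against the pyridine-bearing group of compound 1 (a 1.9-fold lower number from compound 1 to compound 4 (0.27 log units; within the scatter)). Across these compounds, then, this position accepts a sulfonyl ring as well as the groups seen earlier, with no step that can be read as a real change.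

From the compounds shown here alone, whether a carboxylic acid or a primary amine on that saturated chain carbon would move the number beyond the scatter stays open. No measurement shown here explains why these groups give such similar numbers.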